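Trimming an isobutoxy chain on an adenosine antagonist scaffold

The source may report more compounds than this note shows. Statements on the series, on what has been measured and on what is new or still open speak of the compounds shown alone.

Compound 1 `CC(C)COc1ccc(-c2cn3c(=O)n(-c4ccccc4)nc3c(N)n2)cc1` was not measured in a functional assay on cells for antagonist activity at adenosine receptor A2b (Homo sapiens), read by cAMP accumulation, with a stated time of 10 min (a higher number here means a weaker inhibitor, a lower number a stronger inhibitor), so compound 1 gives "not determined" (no result reported) there. Compound 2 `O=c1[nH]c(-c2ccccc2)cn2c(=O)n(-c3ccccc3)nc12` reaches only a limit of the assay, recorded as > 30000 nM. Compound 3 `CCCOc1ccc(-c2cn3c(=O)n(-c4ccccc4)nc3c(N)n2)cc1` has not yet been tested. Compound 3 differs from compound 1 by hydrogen in place of methyl on a saturated chain carbon bound to two saturated chain carbons. No comparable change has been measured here. No step beyond the usual scatter is expected in this assay in either direction. Compound 3 is expected to give an estimated 150 nM, within a range from 10 nM to 3000 nM.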

Compound 3, half-maximal inhibitory concentration: > 30000 nM
Compound 3 ended at the assay's limit (the forecaster's own chance of this, stated with the estimate: 15%); middle value at least 200-fold (2.30 log units) from the limit.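

No step from compound 1 to compound 3 can be read in this assay, since compound 3 gives only a limit of the assay: the limit of > 30000 nM in this assay, at which 2 of the 3 values shown sit.

The compounds shown leave open what the change from isobutoxy to propoxy does to inhibitor strength.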